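Moving the chlorine on the urea ring of a thienopyrimidine

The source may report more compounds than this note shows. Statements on the series, on what has been measured and on what is new or still open speak of the compounds shown alone.

Compound 1 `CN(C)CCCNc1nc(-c2ccc(NC(=O)Nc3ccc(Cl)cc3)cc2)nc2c(Cl)c(Cl)sc12` gives 330 nM in a functional assay on HT-29 cells (Homo sapiens) for cytotoxicity, read by MTT assay, with a stated time of 72 h; on this read-out higher numbers stand for weaker inhibition and lower numbers for stronger inhibition. Compound 2 `CN(C)CCCNc1nc(-c2ccc(NC(=O)Nc3ccccc3Cl)cc2)nc2c(Cl)c(Cl)sc12` gives 820 nM in this assay. The two differ by 2-chlorophenyl in place of 4-chlorophenyl on an amide-type nitrogen, and the step was a 2.5-fold higher number from compound 1 to compound 2 (0.40 log units; beyond the scatter). Compound 3 `CCN(CC)CCNc1nc(-c2ccc(NC(=O)Nc3ccc(Cl)cc3)cc2)nc2c(Cl)c(Cl)sc12` gives 430 nM in this assay; its core differs from the core of compound 1 by diethylamino in place of (dimethylamino)methyl on a saturated chain carbon, two bonds along the chain from a nitrogen on an aromatic ring, a step of a 1.3-fold higher number from compound 1 to compound 3 (0.11 log units; within the scatter). Compound 4 `CCN(CC)CCNc1nc(-c2ccc(NC(=O)Nc3ccccc3Cl)cc2)nc2c(Cl)c(Cl)sc12` is not yet measured; it differs from compound 3 by 2-chlorophenyl in place of 4-chlorophenyl on an amide-type nitrogen, the same change as that from compound 1 to compound 2. Because the step of a 2.5-fold higher number from compound 1 to compound 2 (0.40 log units; beyond the scatter) was modest and the core step a 1.3-fold higher number from compound 1 to compound 3 (0.11 log units; within the scatter) stayed within the scatter, compound 4 is expected to make a step of a 2.3-fold higher number from compound 3 to compound 4 (0.37 log units; beyond the scatter). Compound 4 is estimated at 1000 nM in this assay, expected to fall between 500 nM and 2200 nM.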

Compound 4, half-maximal inhibitory concentration: 550 nM
For compound 4 the middle estimate is 1.8-fold (0.26 log units) above the measured one, and the stated range covers the measured number.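

Carried to the core of compound 3, the swap of 4-chlorophenyl for 2-chlorophenyl gives a 1.3-fold higher number from compound 3 to compound 4 (0.11 log units; within the scatter) in this assay, and this does not differ from its earlier reading: the same change on two cores in this assay, a 2.5-fold higher number (0.40 log units; beyond the scatter) from compound 1 to compound 2 and a 1.3-fold higher number (0.11 log units; within the scatter) from compound 3 to compound 4, 1.9-fold (0.29 log units) apart, within the scatter of two such steps

The side-chain change, read on the two 2-chlorophenyl compounds, gives a 1.5-fold lower number from compound 2 to compound 4 (0.17 log units; within the scatter), which also matches its earlier reading: the same change on two cores in this assay, a 1.3-fold higher number (0.11 log units; within the scatter) from compound 1 to compound 3 and a 1.5-fold lower number (0.17 log units; within the scatter) from compound 2 to compound 4, 1.9-fold (0.29 log units) apart, within the scatter of two such steps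

So neither change shows any dependence on the core here, but two cores are a small test, and the chlorine step lies beyond the scatter on one core and within it on the other, so its size on a further core remains unsettled.

On these data alone, whether 3-chlorophenyl or unsubstituted phenyl on the amide-type nitrogen would fit the same picture stays open. So does the behaviour of a morpholine or pyrrolidine at the end of the side chain.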